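This account rests on a few compounds, and the source may have more. Where it says the series, first, only, none or still open, it means among the compounds named here.

Compound 1 `N#CC1=C(N)Oc2c(N)cc3nc4ccccc4nc3c2C12C(=O)N(Cc1cnnn1-c1cccc(Br)c1)c1ccccc12`: in a functional assay on MCF7 cells (Homo sapiens) for antiproliferative activity, read by MTT assay, with a stated time of 48 h (a higher number here means a weaker inhibitor, a lower number a stronger inhibitor), only a limit, > 50000 nM.
Compound 2 `COc1ccc(OC)c(-n2nncc2CN2C(=O)C3(C(C#N)=C(N)Oc4c(N)cc5nc6ccccc6nc5c43)c3ccccc32)c1`: in this assay 28100 nM.

For the measured compounds named here, compound 2 holds the only actual number here; the other value is a limit of the assay (the limit of > 50000 nM in this assay, at which 1 of the 2 values shown sits). Going by the values given here, the one measured step, an at least 1.7-fold lower number from compound 1 to compound 2 (0.25 log units; that floor lies within the scatter), swaps the aryl group on the aromatic nitrogen. Compound 3 `Cc1ccc(-n2nncc2CN2C(=O)C3(C(C#N)=C(N)Oc4c(N)cc5nc6ccccc6nc5c43)c3ccccc32)cc1Cl` makes a similar swap: 3-chloro-4-methylphenyl in place of 2,5-dimethoxyphenyl on an aromatic nitrogen. Among the compounds with values here, since the only comparable step has a floor within the scatter, no shift beyond the scatter is expected, so compound 3 is estimated at 28000 nM, between 9000 nM and 90000 nM, a step of a 1.0-fold lower number from compound 2 to compound 3 (0.00 log units; within the scatter).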

Compound 3, half-maximal inhibitory concentration: > 50000 nM
Compound 3: no number, only a limit; the forecaster's own chance of this, stated with the estimate: 30%; middle value at least 1.7-fold (0.25 log units) away from the limit.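

Placing 3-chloro-4-methylphenyl on the aromatic nitrogen gives an at least 1.7-fold higher number from compound 2 to compound 3 (0.25 log units; that floor lies within the scatter). The step between compound 1 and compound 3 cannot be read, as both values are limits. Compound 2 stays the only compound with an actual number, while compound 1 and compound 3, with a bromine or a chlorine on their phenyl rings, both stand at the limit: the limit of > 50000 nM in this assay, at which 2 of the 3 values shown sit.

Still open, from the compounds shown here alone, is whether any aryl group on this nitrogen moves the number beyond the scatter. Also open, going by these compounds, is what a phenyl ring carrying an amine or a carboxylic acid would do here.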